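Compound 3 against the aryl sulfonamide pair

The source may hold more compounds than are shown below. What is called first, only, known or untested is meant among the compounds shown, and "the series" means these compounds.

Compound 1 (`Cc1ccc(NS(=O)(=O)c2ccc(N3CCNC3=O)cc2)cc1C`) and compound 2 (`O=C1NCCN1c1ccc(S(=O)(=O)Nc2ccc(F)c(F)c2)cc1`) share one core and differ only in the aryl group on a sulfonamide nitrogen. In a functional assay on HT-29 cells (Homo sapiens) for antiproliferative activity, read by sulforhodamine B assay, with a stated time of 48 h (a higher number here means a weaker inhibitor, a lower number a stronger inhibitor), compound 1 gives 230 nM and compound 2 gives 350 nM so the pair sits within the scatter. For the measured compounds named here, the one measured step is a 1.5-fold higher number from compound 1 to compound 2 (0.18 log units; within the scatter) and it replaces 3,4-dimethylphenyl with 3,4-difluorophenyl. Compound 3 (`CCc1cccc(NS(=O)(=O)c2ccc(N3CCNC3=O)cc2)c1`) has 3-ethylphenyl in place of 3,4-difluorophenyl on a sulfonamide nitrogen. Going by the values given here, no measured compound carries 3-ethylphenyl, so the evidence is indirect. The exchange seen between compound 1 and compound 2 moved the number no further than the scatter, and no change beyond the scatter is therefore expected in this assay here. The expected step is a 1.2-fold lower number from compound 2 to compound 3 (0.07 log units; within the scatter) and no direction is firmly indicated. The estimated value for compound 3 is 300 nM with an expected range of 120 nM to 750 nM as its bounds.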

Compound 3, half-maximal inhibitory concentration: 110 nM
Compound 3: the middle estimate sits 2.7-fold (0.44 log units) above what was measured; the measured number lies below the stated range.
By their numbers in this assay, from the lowest: compound 3; then compounds 1 and 2 (each within the scatter of the next).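

In this assay, the aryl group on a sulfonamide nitrogen proves able to shift the number beyond the scatter, which the earlier exchange alone, a 1.5-fold higher number from compound 1 to compound 2 (0.18 log units; within the scatter), did not show: 3-ethylphenyl in place of 3,4-difluorophenyl gives a 3.2-fold lower number from compound 2 to compound 3 (0.50 log units; beyond the scatter), and 3-ethylphenyl in place of 3,4-dimethylphenyl gives a 2.1-fold lower number from compound 1 to compound 3 (0.32 log units; beyond the scatter). Both steps are modest, and 3,4-difluorophenyl and 3-ethylphenyl match in the computed counts of heavy atoms, rings, hydrogen-bond donors and acceptors, and charge, so those counts do not separate them. No measurement here accounts for the difference.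

Going by these compounds, whether a propyl chain or a methoxy group would give a lower or higher number than ethyl remains open. So does the effect of an amine or a carboxylic acid on this aryl ring.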